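This account rests on a few compounds, and the source may have more. Where it says the series, first, only, none or still open, it means among the compounds named here.

In a functional assay on OVCAR-3 cells (Homo sapiens) for antiproliferative activity (on this read-out lower numbers stand for stronger inhibition of growth and higher numbers for weaker inhibition of growth), compound 1 `Cc1ccnc2nc(-c3cccc(Cl)c3)cc(O)c12` gives 31.6 nM. Compound 2 `Cc1cc(C)c2c(O)cc(-c3cccc(Cl)c3)nc2n1` carries one more methyl group and in this assay gives 170 nM; the change, (methyl in place of hydrogen on an aromatic carbon), made a step of a 5.4-fold higher number from compound 1 to compound 2 (0.73 log units; beyond the scatter). Compound 3 `Cc1ccc2c(O)cc(-c3ccc4ccccc4c3)nc2n1` has a different core, and how its core differs from that of compound 1 is not broken down here. In this assay compound 3 gives 3630 nM, the highest of the three numbers, beyond the scatter from each of the others. Compound 4 `Cc1cc(C)c2c(O)cc(-c3ccc4ccccc4c3)nc2n1` is compound 3 with the same kind of change, (methyl in place of hydrogen on an aromatic carbon). It is the same kind of change rather than the same one, since the place differs: in compound 2 the new methyl sits next to the ring nitrogen and para to a fused ring, while in compound 4 it sits ortho to a fused ring and opposite the ring nitrogen. Among the measured compounds shown here, the only measured example of this change was a modest move to a higher number. A higher number than that of compound 3 is therefore expected for compound 4, with the step estimated at a 2.8-fold higher number from compound 3 to compound 4 (0.44 log units; beyond the scatter). That expectation rests on the measured step of a 5.4-fold higher number from compound 1 to compound 2 (0.73 log units; beyond the scatter), with wider uncertainty since the surroundings of the new methyl are not the same. The value of compound 4 is estimated at 10000 nM, between 3000 nM and 40000 nM.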

Compound 4, concentration for 50% growth inhibition: 20000 nM
Beside the measured number, compound 4's estimate is 2.0-fold (0.30 log units) below it, within the range that was stated.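

On the core of compound 3, methyl in place of hydrogen on an aromatic carbon gave a 5.5-fold higher number from compound 3 to compound 4 (0.74 log units; beyond the scatter) in this assay, so growth inhibition weakened here as it did in the earlier pair. The size of the step also carried over from one core to the other: the same change on two cores in this assay, a 5.4-fold higher number (0.73 log units; beyond the scatter) from compound 1 to compound 2 and a 5.5-fold higher number (0.74 log units; beyond the scatter) from compound 3 to compound 4, 1.0-fold (0.01 log units) apart, within the scatter of two such steps. Among the compounds shown here, this agreement rests on only two pairs, with the new methyl in a different place in each, so it suggests that the penalty can transfer within these compounds but does not show that it would hold on any further core, and it does not explain why the methyl has this effect.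

On these data alone, only hydrogen and methyl are compared at these places, so it remains open whether an ethyl group, a methoxy group, an amine or a fluorine atom would weaken growth inhibition in the same way. As far as these compounds go, it is also open whether a step of this size would appear with a methyl on another ring carbon.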